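Adding a nitrile to compound 1: an expected shift

The compounds below may be only part of what the source reports. "The series", "measured", "known", "first", "only" and "open" are said of these compounds alone.

Compounds measured so far:
compound 1, `Brc1ccc2nc(-c3ccccc3)cc(-c3ccccc3)c2c1`: 128000 nM
compound 2, `O=[N+]([O-])c1ccc2c(-c3ccccc3)cc(-c3ccccc3)nc2c1`: "not determined" (no result reported)

Among the compounds with values here, compound 1 is the only compound with a numerical result in a functional assay on Hep2C cells (Homo sapiens) for antiproliferative activity, read by MTT assay, with a stated time of 24 h; a higher number here means a weaker inhibitor, a lower number a stronger inhibitor; compound 2 has no reported number there, so no step between measured compounds can be drawn. In this assay compound 1 gives 128000 nM, a weak inhibitor.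

Compound 3, `N#Cc1ccc(-c2cc(-c3ccccc3)c3cc(Br)ccc3n2)cc1`, differs from compound 1 by cyano in place of hydrogen on an aromatic carbon, the phenyl becoming 4-cyanophenyl. Without any measured step to lean on, compound 3 is expected to move only modestly toward a stronger inhibitor, a 1.4-fold lower number from compound 1 to compound 3 (0.15 log units; within the scatter), a shift that may well stay within the usual scatter. Compound 3 is therefore estimated at 90000 nM, with a range from 30000 nM to 300000 nM.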

Compound 3, half-maximal inhibitory concentration: 98800 nM
Compound 3: the middle estimate sits 1.1-fold (0.04 log units) below what was measured; the range from low to high includes it.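

In this assay, within the data shown here, a 1.3-fold lower number from compound 1 to compound 3 (0.11 log units; within the scatter) is the first step that can be read, and it lies within the scatter. At this position, on a six-membered aromatic ring of carbon only and para to a large group, phenyl to 4-cyanophenyl therefore does not separate the two compounds, and compound 3 at 98800 nM remains a weak inhibitor. No supporting measurement is available to explain this result.

From the compounds shown here alone, whether an amine or a carboxylic acid at the same position would give a step beyond the scatter remains open. One substituent at one position also does not show whether the other phenyl or the bromine on the shared core would respond in the same way.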